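Truncation of the benzyloxy side chain on the shared core

The source may hold more compounds than are shown below. What is called first, only, known or untested is meant among the compounds shown, and "the series" means these compounds.

Measured so far in a functional assay on A549 cells (Homo sapiens) for inhibition, tested at 1 uM; on this read-out lower numbers stand for a weaker effect and higher numbers for a stronger effect at the one concentration tested:
compound 1, `Cc1ccc(S(=O)(=O)n2cc(-c3cc(C(F)(F)F)c(C#N)c(-c4cn(S(=O)(=O)c5ccc(C)cc5)c5ccc(Br)cc45)n3)c3cc(Br)ccc32)cc1`, 17.4%
compound 2, `Cc1ccc(S(=O)(=O)n2cc(-c3cc(C(F)(F)F)ccn3)c3cc(Br)ccc32)cc1`, 32.8%
compound 3, `Cc1ccc(S(=O)(=O)n2cc(-c3cc(C(F)(F)F)ccn3)c3cc(OCc4ccccc4)ccc32)cc1`, 23.2%

Compound 3 lies within the scatter of both other measured values: its gap to compound 1 and its gap to compound 2 are each of a size that repeated measurement could produce on its own, so no order among the three can be read from the numbers.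

The new compound is compound 4, `COc1ccc2c(c1)c(-c1cc(C(F)(F)F)ccn1)cn2S(=O)(=O)c1ccc(C)cc1`. It differs from compound 3 in one place:

hydrogen in place of phenyl on a saturated chain carbon bound to an oxygen on an aromatic ring

Among the measured compounds shown here, the only measured step at a comparable position is a number 9.6 percentage points lower from compound 2 to compound 3 (within the scatter), which replaced the bromo group by the benzyloxy group and stayed within the scatter. For the measured compounds named here, no measured pair shows the removal of the phenyl from that chain, so nothing in the data points to a step beyond the scatter in either direction. The working expectation is that compound 4 stays near compound 3, with the uncertainty set by the scatter rather than by any shown trend.

Compound 4 is therefore expected to give about 24%, with a range of 11% to 38%. The expected step of a number 0.8 percentage points higher from compound 3 to compound 4 (within the scatter) is estimated to be none beyond the scatter.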

Compound 4, a percentage reported as inhibition, at one concentration (the size of the read-out at that concentration, not a potency): 23.2%
For compound 4 the middle estimate is 0.8 percentage points above the measured one; the measured number falls inside the stated range.
By their numbers in this assay, from the lowest: compounds 1, 3, 4 and 2 (each within the scatter of the next, the first and the last beyond it).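

Working notes: in this assay, the step of no change at the digits printed from compound 3 to compound 4 (within the scatter) comes from the first pair that isolates the phenyl on this chain, and it shows that cutting benzyloxy to methoxy leaves no change beyond the scatter. Taken from the bromo side, methoxy gives a number 9.6 percentage points lower from compound 2 to compound 4 (within the scatter), and benzyloxy gives a number 9.6 percentage points lower from compound 2 to compound 3 (within the scatter), so neither oxygen-linked group at this aromatic carbon separates from bromo, or from the other, beyond the scatter. Among compound 2, compound 3 and compound 4, this position therefore tolerates bromo, methoxy and benzyloxy without a resolved difference in the read-out at the one concentration tested, and no supporting data bear on the reason for this.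

Going by these compounds, whether a free hydroxy group, a chain ending in an amine or a carboxylic acid at this place would shift the read-out beyond the scatter remains open. Also open, on these data alone, is whether compound 2, compound 3 and compound 4 would separate in the size of their effect at other concentrations, as a single-concentration percentage cannot show how their concentration responses compare.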